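Trimming the Side Chain of Compound 3

The source may hold more compounds than are shown below. What is called first, only, known or untested is meant among the compounds shown, and "the series" means these compounds.

Compound 3 `CC(C)Cc1nc2c(-c3ccccc3)cc(-c3ccccc3)nc2[nH]1` gives the lowest number of the three compounds measured in an assay on CHO cells for displacement of a labelled ligand from adenosine receptor A3 (Homo sapiens); on this read-out higher numbers stand for weaker inhibition and lower numbers for stronger inhibition: for compound 3 the value is 25 nM. The compound with hydrogen at the same place, compound 1 `c1ccc(-c2cc(-c3ccccc3)c3nc[nH]c3n2)cc1`, gives 180 nM, and compound 2 `CCC(CC)c1nc2c(-c3ccccc3)cc(-c3ccccc3)nc2[nH]1`, which carries pentan-3-yl there, gives 171 nM. Both sit clearly above compound 3: the step of a 7.2-fold lower number from compound 1 to compound 3 (0.86 log units; beyond the scatter) and the step of a 6.8-fold lower number from compound 2 to compound 3 (0.84 log units; beyond the scatter) are each beyond the scatter, while the step of a 1.1-fold lower number from compound 1 to compound 2 (0.02 log units; within the scatter) shows that hydrogen and pentan-3-yl cannot be told apart.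

Compound 4 `Cc1nc2c(-c3ccccc3)cc(-c3ccccc3)nc2[nH]1` shortens the chain of compound 3: hydrogen in place of isopropyl on a saturated chain carbon bound to an aromatic carbon. Put differently, the isobutyl of compound 3 becomes a methyl. Going by the values given here, no measured pair makes exactly this change, but the two steps that lead to compound 3 frame it: the chain from hydrogen to isobutyl gave a modest gain, and the change from pentan-3-yl to isobutyl gave a gain of similar size. Methyl is shorter than isobutyl and longer than hydrogen, so the number for compound 4 is expected to rise from compound 3 toward compound 1 without reaching it, a step of a 3.2-fold higher number from compound 3 to compound 4 (0.51 log units; beyond the scatter) in this assay. The estimate for compound 4 is therefore 80 nM, with a range from 25 nM to 250 nM.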

Compound 4, inhibition constant: 61 nM
Compound 4: middle estimate off by 1.3-fold (0.12 log units), on the high side; low and high end bracket the measured number.
By their numbers in this assay, from the lowest: compound 3; then compound 4; then compounds 2 and 1 (each within the scatter of the next).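

In this assay even the short methyl of compound 4 keeps part of the gain over hydrogen, with a 3.0-fold lower number from compound 1 to compound 4 (0.47 log units; beyond the scatter) as the step, so this position responds to a group much shorter than isobutyl. Methyl also gives a lower number than pentan-3-yl, with a 2.8-fold lower number from compound 2 to compound 4 (0.45 log units; beyond the scatter) on that change, yet it falls short of isobutyl, with a 2.4-fold higher number from compound 3 to compound 4 (0.39 log units; beyond the scatter) on trimming the chain, so the isopropyl lost from compound 3 accounts for part of that compound's advantage. The numbers fall from hydrogen through methyl to isobutyl, compound 2 with its pentan-3-yl goes against that run, and nothing available explains why the groups rank in this order.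

The compounds shown leave open where an ethyl, a propyl or a longer unbranched chain such as pentyl would fall, and so whether isobutyl lies near the best of the simple chains at this position. They also leave open how a chain ending in an amine or a carboxylic acid would compare with the plain carbon chains.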